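A few compounds are considered here, and "the series" means these few. Any claim that something is new, unique, unknown or untested is made for them only; others in the source may bear on it.

Measured compounds in a functional assay on SK-BR-3 cells (Homo sapiens) for antiproliferative activity, read by MTT assay, with a stated time of 48 h; a lower number here means a stronger inhibitor, a higher number a weaker inhibitor:
compound 1, `Cc1ccc(C(F)(F)F)cc1COc1cc(NC(=O)c2ccc(Br)cc2)ccc1N(C)S(C)(=O)=O`, gives 9490 nM
compound 2, `COc1ccc(C(=O)Nc2ccc(N(C)S(C)(=O)=O)c(OCc3cc(C(F)(F)F)ccc3C)c2)cc1`, gives 2030 nM
compound 3, `Cc1ccc(C)c(COc2cc(NC(=O)c3ccc(Br)cc3)ccc2N(C)S(=O)(=O)C(F)(F)F)c1`, gives 36400 nM

Compound 2 differs from compound 1 by one change, (methoxy in place of bromo on an aromatic carbon), and this gave a 4.7-fold lower number from compound 1 to compound 2 (0.67 log units; beyond the scatter). Compound 3 holds the highest number of the three in this assay; how its core differs from that of compound 1 is not broken down here.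

Compound 4, `COc1ccc(C(=O)Nc2ccc(N(C)S(=O)(=O)C(F)(F)F)c(OCc3cc(C)ccc3C)c2)cc1`, stands to compound 3 as compound 2 stands to compound 1: methoxy in place of bromo on an aromatic carbon. The place is described in the same words in both pairs, so this is the same change on a different core.

Taking the single measured instance as the guide, a step of about the same size is expected for compound 4, namely a 4.3-fold lower number from compound 3 to compound 4 (0.63 log units; beyond the scatter), since the change from compound 1 to compound 2 gave a 4.7-fold lower number from compound 1 to compound 2 (0.67 log units; beyond the scatter). Among the measured compounds shown here, with only one precedent the range is kept wide. Compound 4 is therefore estimated at 8500 nM in this assay, between 3000 nM and 25000 nM.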

Compound 4, half-maximal inhibitory concentration: 5320 nM
Compound 4: middle estimate off by 1.6-fold (0.20 log units), on the high side; low and high end bracket the measured number.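

In this assay methoxy in place of bromo on the core of compound 3 gives a 6.8-fold lower number from compound 3 to compound 4 (0.84 log units; beyond the scatter) on this second core. The change carries over between these two cores, but this says nothing about its size on any other core, nor why it lowers the number. The two steps agree in size: the same change on two cores in this assay, a 4.7-fold lower number (0.67 log units; beyond the scatter) from compound 1 to compound 2 and a 6.8-fold lower number (0.84 log units; beyond the scatter) from compound 3 to compound 4, 1.5-fold (0.17 log units) apart, within the scatter of two such steps

Only 4-bromophenyl and 4-methoxyphenyl are shown at this place, so it remains open whether the step is particular to methoxy or would also appear with a hydroxy group, an amine or a nitrile. Also open is how each of the differences between the two cores acts alone, as no pair shown isolates one of them.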